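This account rests on a few compounds, and the source may have more. Where it says the series, first, only, none or still open, it means among the compounds named here.

Measured in a functional assay on ASPC1 cells (Homo sapiens) for antiproliferative activity, read by sulforhodamine B assay, with a stated time of 48 h; on this read-out higher numbers stand for weaker inhibition and lower numbers for stronger inhibition
- compound 1 `O=C(CCCCCCN1C(=O)/C(=N\O)c2ccccc21)NO` gives 1100 nM
- compound 2 `O=C(CCCCCCN1C(=O)/C(=N\O)c2cc(Br)ccc21)NO` gives 80 nM

Compound 2 holds the lower of the two numbers. Compound 3 `Cc1ccc2c(c1)/C(=N/O)C(=O)N2CCCCCCC(=O)NO` keeps the shared core and carries methyl in place of bromo on an aromatic carbon. Within the data shown here, one measured step bears on this place, and it is large: a 14-fold lower number from compound 1 to compound 2 (1.14 log units; beyond the scatter) with bromo in place of hydrogen on an aromatic carbon. No methyl has been measured here, so part of that gain is expected to be lost, giving a higher number. The expected size is a 2.5-fold higher number from compound 2 to compound 3 (0.40 log units; beyond the scatter) in this assay and would lie modestly beyond the scatter. Estimated for compound 3: 200 nM (range 70 nM to 600 nM).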

Compound 3, half-maximal inhibitory concentration: 2440 nM
For compound 3 the middle estimate is 12-fold (1.09 log units) below the measured one, outside the stated range (above it).
By their numbers in this assay, from the lowest: compound 2; then compound 1; then compound 3.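

Hydrogen replaced on this aromatic carbon does not by itself lower the number: methyl gives a 2.2-fold higher number from compound 1 to compound 3 (0.35 log units; beyond the scatter) and so runs against bromo. Methyl in place of bromo is the largest step among these compounds, with a 31-fold higher number from compound 2 to compound 3 (1.48 log units; beyond the scatter) at this one place, so the outcome turns on which group sits there. Nothing available explains the gap between the two groups.

Open, going by these compounds, is whether chloro or fluoro on this aromatic carbon would follow bromo or methyl. On these data alone, an amine or a carboxylic acid there is equally open.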